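The compounds below may be only part of what the source reports. "The series", "measured", "known", "first", "only" and "open" are said of these compounds alone.

Measured in a functional assay on MIA PaCa-2 cells (Homo sapiens) for cytotoxicity, read by fluorescence, with a stated time of 48 h; a higher number here means that more compound is needed for the effect, a lower number that less compound is needed:
- Compound 1 `CC(C)=CCC/C(C)=C/CC/C(C)=C/CSC[C@H](NC(=O)CCCCCN1CCN(C)CC1)C(=O)NC1CCCCCCC1`: 2500 nM
- Compound 2 `CC(C)=CCC/C(C)=C/CC/C(C)=C/CSC[C@H](NC(=O)CCCCCN1CCCC1)C(=O)NC1CCCCCCC1`: 1900 nM
- Compound 3 `CC(C)=CCC/C(C)=C/CC/C(C)=C/CSC[C@H](NC(=O)CCCCCN1CCCC1)C(=O)NC1CC1`: > 20000 nM (a limit)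

Compound 1, at 2500 nM, sits level with its nearest neighbour, given a 1.3-fold lower number from compound 1 to compound 2 (0.12 log units; within the scatter). Compound 4 `CC(C)=CCC/C(C)=C/CC/C(C)=C/CSC[C@H](NC(=O)CCCCCN1CCN(C)CC1)C(=O)NC1CCCCC1` keeps the core of compound 1 but places cyclohexyl in place of cyclooctyl on an amide-type nitrogen. The closest guide is the change at that same place, an at least 10-fold higher number from compound 2 to compound 3 (1.02 log units; beyond the scatter), a large step to cyclopropyl. Cyclohexyl stands nearer to cyclooctyl than cyclopropyl does, so a much smaller step towards a higher number is expected in this assay. The estimated step is a 1.4-fold higher number from compound 1 to compound 4 (0.15 log units; within the scatter). Compound 4 is expected at 3500 nM, with an estimated range of 1800 nM to 9000 nM.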

Compound 4, half-maximal effective concentration: 5900 nM
Compound 4: middle estimate off by 1.7-fold (0.23 log units), on the low side; the measured number falls inside the stated range.
By their numbers in this assay, from the lowest: compounds 2 and 1 (each within the scatter of the next); then compound 4. At a limit, above all of these: compound 3.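

Cyclohexyl in place of cyclooctyl on the amide-type nitrogen gives a 2.4-fold higher number from compound 1 to compound 4 (0.37 log units; beyond the scatter) in this assay. A modest shift therefore already appears with the six-membered ring, whereas earlier only the change to cyclopropyl, made with a different side chain, had moved the number at this position. Compound 3 stands at a limit, so the full size of its step cannot be read: the limit of > 20000 nM in this assay, at which 1 of the 4 values shown sits.

On these data alone, whether cycloheptyl or an open-chain alkyl group on this nitrogen would stay level with cyclooctyl remains open. So does whether cyclohexyl gives a similar step with the pyrrolidin-1-yl side chain.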